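The source may hold more compounds than are shown below. What is called first, only, known or untested is meant among the compounds shown, and "the series" means these compounds.

Three compounds have been measured so far in an ADME assay on HEK-293T cells (Homo sapiens) for cytotoxicity, read by luminescence, with a stated time of 24 h (a higher number here means that more compound is tolerated, a lower number that less compound is tolerated), and each gives only a limit:

- Compound 1 `COc1ccc(Cn2c(C(N)=O)cc3sccc32)cc1` gives > 100000 nM as a limit
- Compound 2 `COc1ccc(Cn2c(C(=O)NCc3ccccc3)cc3sccc32)cc1` gives > 100000 nM as a limit
- Compound 3 `CCN(CC)C(=O)c1cc2sccc2n1Cc1ccc(OC)cc1` gives > 100000 nM as a limit

Compound 3 therefore has no exact number, and all three compounds stand at one place (the limit of > 100000 nM in this assay, at which 3 of the 3 values shown sit). Compound 4 `COc1ccc(Cn2c(C(=O)N3CCCC3)cc3sccc32)cc1` carries pyrrolidin-1-yl in place of diethylamino on a carbonyl carbon. Three measured changes on that carbonyl carbon bear on this (a step that the two limits leave unreadable from compound 1 to compound 2) (a step that the two limits leave unreadable from compound 1 to compound 3) (a step that the two limits leave unreadable from compound 2 to compound 3) and none of them has a readable size. With the closest of them being a step that the two limits leave unreadable from compound 2 to compound 3 as the guide, no step beyond the scatter is expected in this assay here. The expected step is a number no higher from compound 3 to compound 4 (the limit leaves the size open) and it is only an estimate. For compound 4 the estimate is 100000 nM with an expected range from 50000 nM to 200000 nM and another limit is likely.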

Compound 4, half-maximal cytotoxic concentration: > 100000 nM
Compound 4 gave a limit, no number; the forecaster's own chance of this, stated with the estimate: 90%; the middle value sits exactly at the limit.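

In this assay no step can be read from compound 4 to compound 1, compound 2 or compound 3, because all four sit at one limit: the limit of > 100000 nM in this assay, at which 4 of the 4 values shown sit. The compounds shown leave open whether any change on the carbonyl carbon alters how much compound the cells tolerate.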